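Sulfanyl to sulfonyl exchange in the hydroxyphenyl amide series

The source may hold more compounds than are shown below. What is called first, only, known or untested is meant among the compounds shown, and "the series" means these compounds.

Three members of the series have been measured in a functional assay on LNCaP cells (Homo sapiens) for antiproliferative activity, read by fluorescence and propidium iodide staining, with a stated time of 96 h; a lower number here means a stronger inhibitor, a higher number a weaker inhibitor. Compound 1 `O=C(Nc1ccc([N+](=O)[O-])c(C(F)(F)F)c1)c1ccc(Sc2ccc(O)cc2)cc1` gives 3580 nM in this assay. Compound 2 `O=C(Nc1cc(C(F)(F)F)cc(C(F)(F)F)c1)c1ccc(Sc2ccc(O)cc2)cc1` gives 2390 nM in this assay. Compound 3 `O=C(Nc1ccc([N+](=O)[O-])c(C(F)(F)F)c1)c1ccc(S(=O)(=O)c2ccc(O)cc2)cc1` gives 4960 nM in this assay. Within the data shown here, the numbers for compound 2 and compound 1 lie within the scatter of each other, and only the gap from compound 2 to compound 3 lies beyond it, so no compound is singled out as the most potent. The difference between the cores of compound 1 and compound 2 is not broken down here.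

Compound 1 and compound 3 differ in one place: (4-hydroxyphenyl)sulfonyl in place of (4-hydroxyphenyl)sulfanyl on an aromatic carbon. The measured step of a 1.4-fold higher number from compound 1 to compound 3 (0.14 log units; within the scatter) is within the scatter.

Compound 4 `O=C(Nc1cc(C(F)(F)F)cc(C(F)(F)F)c1)c1ccc(S(=O)(=O)c2ccc(O)cc2)cc1` has not yet been measured in this assay. It stands to compound 2 as compound 3 stands to compound 1: (4-hydroxyphenyl)sulfonyl in place of (4-hydroxyphenyl)sulfanyl on an aromatic carbon. The place of the change reads the same in both pairs, so this is the same change, seen twice among the compounds shown. Among the measured compounds shown here, the step from compound 2 to compound 4 is expected to be of similar size, a 1.4-fold higher number from compound 2 to compound 4 (0.14 log units; within the scatter), because the one measured instance a 1.4-fold higher number from compound 1 to compound 3 (0.14 log units; within the scatter) stayed within the scatter. This expectation rests on a single measured pair and on nothing else. For compound 4 the expected value in this assay is 3300 nM, with the estimate spanning 1700 nM to 6500 nM.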

Compound 4, half-maximal inhibitory concentration: 8410 nM
For compound 4 the middle estimate is 2.5-fold (0.41 log units) below the measured one; the measured number lies above the stated range.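

In this assay, putting (4-hydroxyphenyl)sulfonyl in place of (4-hydroxyphenyl)sulfanyl on the core of compound 2 gives a 3.5-fold higher number from compound 2 to compound 4 (0.55 log units; beyond the scatter), while the same change on the core of compound 1 gives a 1.4-fold higher number from compound 1 to compound 3 (0.14 log units; within the scatter). Among these compounds, although only the first of these steps lies beyond the scatter, the two steps cannot be told apart, so the data give no firm sign that the outcome of this change depends on the core: the same change on two cores in this assay, a 1.4-fold higher number (0.14 log units; within the scatter) from compound 1 to compound 3 and a 3.5-fold higher number (0.55 log units; beyond the scatter) from compound 2 to compound 4, 2.5-fold (0.40 log units) apart, within the scatter of two such steps This does not show that the step has the same size on both cores, and with only two pairs no general rule for the change can be claimed, the pair of compound 1 and compound 3 being the one that shows no step beyond the scatter.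

The compounds shown leave open how this step would behave with other links in place of the sulfur-containing one, such as a sulfinyl group, an ether oxygen or a methylene, or with a methoxy group or an amine in place of the hydroxyl. They also leave open how the nitro and trifluoromethyl groups of the core of compound 1 each contribute, since no pair shown changes one of them alone.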